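The compounds below may be only part of what the source reports. "The series", "measured", "known", "first", "only" and "open" are said of these compounds alone.

Measured so far:
compound 1, `CCN1CCCC1CNC(=O)c1cc(NS(C)(=O)=O)c(Cl)cc1OC`, in a functional assay on the whole organism for inhibition, with Mus musculus as the target (a lower number here means that less compound is needed, a higher number that more compound is needed for the effect), 9.1 mg/kg;
compound 2, `CCN1CCCC1CNC(=O)c1cc(NS(=O)(=O)NC)ccc1OC`, in this assay > 50 mg/kg.

For compound 2 that reading is only a limit of the assay, not a measured number, as shown by the limit of > 50 mg/kg in this assay, at which 1 of the 2 values shown sits. Compound 3, `CCN1CCCC1CNC(=O)c1cc(NS(=O)(=O)NC)c(Cl)cc1OC`, differs from compound 2 by chloro in place of hydrogen on an aromatic carbon. Within the data shown here, no step between two measured compounds has been worked out here, so the size of the change in this assay is an expectation only: a move toward less compound needed, of moderate size, seems likely. Compound 3 is expected to give 20 mg/kg, between 7 mg/kg and 50 mg/kg. The expected step is an at least 2.5-fold lower number from compound 2 to compound 3 (0.39 log units; beyond the scatter).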

Compound 3, dose for half-maximal effect: > 50 mg/kg
Compound 3 was reported as a limit; the forecaster's own chance of this, stated with the estimate: 35%; middle value at least 2.5-fold (0.39 log units) away from the limit.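

In this assay, with chloro kept on the ring, methylamino in place of methyl on a sulfonyl sulfur gives an at least 5.4-fold higher number from compound 1 to compound 3 (0.73 log units; beyond the scatter), so this change at the sulfonyl sulfur clearly costs activity. Chloro alone does not bring the methylamino compounds back to the level of compound 1. The step for chloro in place of hydrogen cannot be read, because compound 2 and compound 3 both sit at a limit of the assay: the limit of > 50 mg/kg in this assay, at which 2 of the 3 values shown sit.

Going by these compounds, how much chloro contributes stays open, as does the true size of the methylamino loss. Also open, on these data alone, is how an ethyl or a dimethylamino group on the sulfonyl sulfur would read.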